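The source may report more compounds than this note shows. Statements on the series, on what has been measured and on what is new or still open speak of the compounds shown alone.

Compound 1 `O=C(O)c1cn(C2CC2)c2nc(N3CCN(C(c4ccccc4)c4ccc(Cl)cc4)CC3)c([N+](=O)[O-])cc2c1=O` carries a cyclopropyl on an aromatic nitrogen of its core. In an ADME assay on Vero cells (Chlorocebus sabaeus) for cytotoxicity, read by MTT assay, with a stated time of 72 h (a higher number here means a weaker inhibitor, a lower number a stronger inhibitor), compound 1 gives 112000 nM. Compound 3 `O=C(O)c1cn(-c2ccc(F)cc2)c2nc(N3CCN(C(c4ccccc4)c4ccc(Cl)cc4)CC3)c([N+](=O)[O-])cc2c1=O` differs from compound 1 by 4-fluorophenyl in place of cyclopropyl on an aromatic nitrogen. In this assay compound 3 gives 102000 nM, so this change made a 1.1-fold lower number from compound 1 to compound 3 (0.04 log units; within the scatter). Compound 2 `CCN(CC)C(=O)C1CCCN(c2nc3c(cc2[N+](=O)[O-])c(=O)c(C(=O)O)cn3C2CC2)C1` rests on another core; how the two cores differ is not broken down here. In this assay compound 2 gives only a limit of the assay, > 136000 nM. That is the limit of > 136000 nM in this assay, at which 1 of the 3 values shown sits. Compound 4 `CCN(CC)C(=O)C1CCCN(c2nc3c(cc2[N+](=O)[O-])c(=O)c(C(=O)O)cn3-c2ccc(F)cc2)C1` differs from compound 2 by 4-fluorophenyl in place of cyclopropyl on an aromatic nitrogen, the same change as before, at the same place. The expected step is a step that the limit leaves unreadable from compound 2 to compound 4, because the same change gave a 1.1-fold lower number from compound 1 to compound 3 (0.04 log units; within the scatter). Compound 4 is therefore expected to give 140000 nM, with a range from 80000 nM to 250000 nM.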

Compound 4, half-maximal inhibitory concentration: > 122000 nM
Compound 4 gave a limit, no number (the forecaster's own chance of this, stated with the estimate: 60%); the middle value is on the limit's open side.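

Within the data shown here, compound 2 and compound 4 each give only a limit in this assay, not a number, so no step between them can be read. The compounds shown leave open whether 4-fluorophenyl in place of cyclopropyl changes the result on this core.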